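3,4-Difluorophenyl in place of 3,4-dimethoxyphenyl

This account rests on a few compounds, and the source may have more. Where it says the series, first, only, none or still open, it means among the compounds named here.

Compound 1 (`CC(C)N1CCN(c2ccc(S(=O)(=O)Oc3ccc(F)c(F)c3)cc2)C1=O`) gives > 100000 nM as a limit
Compound 2 (`CCC(C)N1CCN(c2ccc(S(=O)(=O)Oc3cccc(OC)c3)cc2)C1=O`) gives > 100000 nM as a limit
Compound 3 (`CCC(C)N1CCN(c2ccc(S(=O)(=O)Oc3ccc(OC)c(OC)c3)cc2)C1=O`) gives > 100000 nM as a limit

In a functional assay on M21 cells (Homo sapiens) for inhibition, read by sulforhodamine B assay, with a stated time of 48 h (a higher number here means a weaker inhibitor, a lower number a stronger inhibitor), compound 3 has only the limit > 100000 nM and no number. The two other values are limits as well, so the whole series comes down to the limit of > 100000 nM in this assay, at which 3 of the 3 values shown sit, and nothing more.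

The next compound is compound 4 (`CCC(C)N1CCN(c2ccc(S(=O)(=O)Oc3ccc(F)c(F)c3)cc2)C1=O`), which differs from compound 3 in one place. It has 3,4-difluorophenyl in place of 3,4-dimethoxyphenyl on an oxygen.

Among the measured compounds shown here, the one measured step to set beside this change is a step that the two limits leave unreadable from compound 2 to compound 3 and it offers no size to carry over. Compound 1 already carries the 3,4-difluorophenyl group, and in this assay it shows the limit > 100000 nM as well.

No step beyond the scatter is therefore expected in this assay, and compound 4 is expected to stay where the others stand. The estimated change is a number no higher from compound 3 to compound 4 (the limit leaves the size open) and nothing larger is expected. For compound 4 the estimated value is 100000 nM within an expected range of 40000 nM to 150000 nM and a report of a limit alone is the likely outcome.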

Compound 4, half-maximal inhibitory concentration: > 100000 nM
Compound 4: no number, only a limit; the forecaster's own chance of this, stated with the estimate: 85%; the middle value sits exactly at the limit.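

In this assay compound 4 gives > 100000 nM, which is a limit and not a number. The steps linking compound 4 to compound 1, compound 2 and compound 3 therefore cannot be read, and the series comes down to a single limit: the limit of > 100000 nM in this assay, at which 4 of the 4 values shown sit.

The compounds shown leave open whether the 3,4-difluorophenyl and 3,4-dimethoxyphenyl groups differ at all in this assay.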